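This account rests on a few compounds, and the source may have more. Where it says the series, first, only, none or still open, it means among the compounds named here.

In a functional assay on K562 cells (Homo sapiens), read by MTT assay, with a stated time of 72 h (a higher number here means a weaker inhibitor, a lower number a stronger inhibitor), four nucleoside analogues built on one shared core are compared. Compound 1 `O=c1[nH]cnc2c1c(-c1ccco1)cn2[C@@H]1O[C@H](CO)[C@@H](O)[C@H]1O` carries a furan-2-yl group and compound 2 `O=c1[nH]cnc2c1c(-c1cc3ccccc3o1)cn2[C@@H]1O[C@H](CO)[C@@H](O)[C@H]1O` a 1-benzofuran-2-yl group at the same position; compound 3 `CNc1ncnc2c1c(-c1cc3ccccc3o1)cn2[C@@H]1O[C@H](CO)[C@@H](O)[C@H]1O` and compound 4 `CNc1ncnc2c1c(-c1ccco1)cn2[C@@H]1O[C@H](CO)[C@@H](O)[C@H]1O` bear the same two groups on a core in which a methylamino group stands where compounds 1 and 2 hold a lactam. The difference between the two cores is not broken down here.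

In this assay compound 1 gives 17800 nM. For compound 2 the result is a limit of the assay, > 20000 nM, and not a number. For compound 3 likewise only a limit is known, > 20000 nM. Going by the values given here, the one measured step, an at least 1.1-fold lower number from compound 2 to compound 1 (0.05 log units; that floor lies within the scatter), is furan-2-yl in place of 1-benzofuran-2-yl on an aromatic carbon and amounts to a change that cannot be distinguished from no change, since the limit of > 20000 nM in this assay, at which 2 of the 3 values shown sit, leaves the size of the step open.

The change from compound 3 to compound 4 is the same: furan-2-yl in place of 1-benzofuran-2-yl on an aromatic carbon. Because the measured step of an at least 1.1-fold lower number from compound 2 to compound 1 (0.05 log units; that floor lies within the scatter) is small or unresolved, compound 4 is expected to sit near the limit of compound 3, with an estimated step of a number no higher from compound 3 to compound 4 (the limit leaves the size open). Compound 4 is therefore estimated at 20000 nM, with the expected range running from 8000 nM to 60000 nM, and a real chance remains that this assay again reports only a limit.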

Compound 4, half-maximal inhibitory concentration: 15100 nM
Compound 4: middle estimate off by 1.3-fold (0.12 log units), on the high side, and the stated range covers the measured number.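

In this assay, furan-2-yl in place of 1-benzofuran-2-yl on the methylamino core gives an at least 1.3-fold lower number from compound 3 to compound 4 (0.12 log units; that floor lies within the scatter). The same change on the lactam core can be set beside this one only through two floors, so the comparison stays loose: the same change on two cores in this assay, an at least 1.1-fold lower number (0.05 log units; that floor lies within the scatter) from compound 2 to compound 1 and an at least 1.3-fold lower number (0.12 log units; that floor lies within the scatter) from compound 3 to compound 4; the limit leaves it open whether they differ The two pairs show that nothing in these data speaks against carrying the change from one core to the other, but they do not show that it has a real effect on either core, or that its size is the same on both, since each benzofuran partner gives only a limit: the limit of > 20000 nM in this assay, at which 2 of the 4 values shown sit.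

The compounds shown leave open how the number in this assay would respond to other groups on that aromatic carbon, such as a thiophen-2-yl group, a phenyl ring or a short chain ending in an amine, any of which might give a measured number on both cores. They also leave open what an unsubstituted amino group or a dimethylamino group would give in the place of the methylamino group, with either furan-2-yl or 1-benzofuran-2-yl on the shared core.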